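A Hydroxy Group Placed Elsewhere on the Shared Core

The compounds below may be only part of what the source reports. "The series", "measured", "known", "first", "only" and "open" are said of these compounds alone.

Compound 2 `O=C1c2ccccc2O[C@H](c2cccc(O)c2O)[C@H]1O` returns only a limit in a functional assay on RAW264.7 cells (Rattus norvegicus) for inhibition, with RAW264.7 (Mus musculus) as the target, read by Griess assay, with stated times of 2 h and 16 h; a higher number here means a weaker inhibitor, a lower number a stronger inhibitor: compound 2 stands at > 100000 nM. Compound 1 `COc1ccc2c(c1)C(=O)[C@H](O)[C@@H](c1cccc(O)c1O)O2` likewise gives a limit, and in this assay compound 1 shows > 100000 nM. Both sit at the limit of > 100000 nM in this assay, at which 2 of the 3 values shown sit. Compound 3 `O=C1c2ccc(O)cc2O[C@H](c2cccc(O)c2O)[C@H]1O` carries a hydroxy in place of hydrogen on an aromatic carbon, and in this assay compound 3 gives 70700 nM, a move of an at least 1.4-fold lower number from compound 2 to compound 3 (0.15 log units; that floor lies within the scatter). Compound 4 `O=C1c2cc(O)ccc2O[C@H](c2cccc(O)c2O)[C@H]1O` differs from compound 2 by hydroxy in place of hydrogen on an aromatic carbon. Within the data shown here, only the step from compound 2 to compound 3 bears on this change, and its floor lies within the scatter, so for compound 4 the expected move is a number no higher from compound 2 to compound 4 (the limit leaves the size open), nothing beyond the scatter. Compound 4 is therefore estimated at 100000 nM, within 40000 nM to 300000 nM.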

Compound 4, half-maximal inhibitory concentration: > 100000 nM
Compound 4: a limit, no number; the forecaster's own chance of this, stated with the estimate: 60%; the middle value sits exactly at the limit.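

In this assay compound 4 also returns only a limit, > 100000 nM. Among these compounds, no step from compound 1 or compound 2 to compound 4 can be read. The compounds shown leave open whether hydroxy at this place changes the number at all.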